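This account rests on a few compounds, and the source may have more. Where it says the series, first, only, none or still open, it means among the compounds named here.

Of the compounds shown here, two have so far been measured in a functional assay on SK-MEL-2 cells (Homo sapiens) for inhibition, read by sulforhodamine B assay, with a stated time of 48 h; a lower number here means a stronger inhibitor of growth, a higher number a weaker inhibitor of growth. Compound 1, whose structure is `N#C/C(=C\N1CCN(C(=O)c2ccco2)C1=S)C(=O)Nc1ccc(Cl)cc1`, gives 16700 nM. Compound 2, a smaller molecule with the structure `O=CN1CCN(c2ccc(Cl)cc2)C1=S`, gives 16300 nM in this assay. Of the two numbers, that of compound 2 is the lower, but the distance to compound 1 is so small that it lies within the scatter of repeated measurements, so the two cannot be told apart.

Compound 3, with the structure `O=CN1CCN(c2ccc(Cl)c(Cl)c2)C1=S`, has not yet been measured in this assay. It differs from compound 2 in one place: chloro in place of hydrogen on an aromatic carbon. Among the compounds with values here, no pair of measured compounds shows the effect of such an exchange, so nothing measured tells how large the step will be. Compound 1 and compound 2 differ widely in structure, yet compound 1 gives 16700 nM and compound 2 gives 16300 nM, nearly the same number. A single added chloro is therefore expected to move the number only a little, with a slight lean toward stronger growth inhibition that stays within the scatter, so the step is expected to be a 1.4-fold lower number from compound 2 to compound 3 (0.13 log units; within the scatter). For compound 3 the estimate is 12000 nM, within a range from 4000 nM to 35000 nM.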

Compound 3, concentration for 50% growth inhibition: 15300 nM
The estimate for compound 3 lay 1.3-fold (0.11 log units) below the measured number; measured number inside the range.
By their numbers in this assay, from the lowest: compounds 3, 2 and 1 (each within the scatter of the next).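

In this assay, a chloro on the aromatic carbon ortho to a chloro group and meta to a group of 8 heavy atoms gives a 1.1-fold lower number from compound 2 to compound 3 (0.03 log units; within the scatter). Within the data shown here, this is the first measured exchange at a single place in this set, and it shows that this ring position can carry a chloro in place of hydrogen with no difference that can be told from the scatter, so compound 2 and compound 3 cannot be separated by this read-out. No measurement is available that bears on why this exchange has so small an effect.

Going by these compounds, one exchange cannot show whether this position is insensitive to groups in general, so it remains open whether a methoxy, an amine or a carboxylic acid in the same place would give a similarly small step or a much larger one. On these data alone, it also remains open whether a second chloro on the aromatic ring of compound 1, which has a very different structure around that ring, would give a step as small as this one.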